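The source may hold more compounds than are shown below. What is called first, only, known or untested is meant among the compounds shown, and "the series" means these compounds.

- compound 1 `O=Cc1cn(Cc2ccc(Cl)cc2)c2ccc(F)cc12` gives 290 nM
- compound 2 `OCc1cn(Cc2ccc(Cl)cc2)c2ccccc12` gives 16 nM

In a functional assay on NCI-H460 cells (Homo sapiens) for cytotoxicity, read by sulforhodamine B assay, with a stated time of 3 days (on this read-out lower numbers stand for stronger inhibition and higher numbers for weaker inhibition), compound 2 has the lower of the two numbers, and the gap to compound 1 lies beyond the scatter. Compound 3 `OCc1cn(Cc2ccc(Cl)cc2)c2ccc(F)cc12` carries fluoro in place of hydrogen on an aromatic carbon of compound 2 (fluoro in place of hydrogen on an aromatic carbon). Among the compounds with values here, no two measured compounds differ in one place only, so the data offer no direct guide to this change. A single swap of this kind is expected to shift the number in this assay by no more than the scatter, which makes any direction uncertain. The expected step is a 1.6-fold higher number from compound 2 to compound 3 (0.19 log units; within the scatter). Compound 3 is estimated at 25 nM, with an expected range of 7 nM to 90 nM.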

Compound 3, half-maximal inhibitory concentration: 30 nM
The estimate for compound 3 lay 1.2-fold (0.08 log units) below the measured number; low and high end bracket the measured number.
By their numbers in this assay, from the lowest: compounds 2 and 3 (each within the scatter of the next); then compound 1.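

In this assay, fluoro in place of hydrogen on an aromatic carbon stays within the scatter (a 1.9-fold higher number from compound 2 to compound 3 (0.27 log units; within the scatter)), so this position of the shared core tolerates fluoro. With fluoro present in both compounds, hydroxymethyl in place of formyl gives a clear step (a 9.7-fold lower number from compound 1 to compound 3 (0.99 log units; beyond the scatter)), the first single-place comparison showing that this group matters. No measured evidence explains either step.

Going by these compounds, whether a larger group at the fluoro position, such as methoxy or trifluoromethyl, would also be tolerated remains open. So does the effect of replacing hydroxymethyl with an amine or a carboxylic acid.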